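Swapping a Fluoro Group for Hydrogen on Compound 2

The source may report more compounds than this note shows. Statements on the series, on what has been measured and on what is new or still open speak of the compounds shown alone.

Measured so far in a physicochemical assay for solubility, at pH 7.4 (on this read-out higher numbers stand for higher solubility and lower numbers for lower solubility), are two compounds:
Compound 1 `Cc1ccc(NC(=O)Nc2cc(C)nc3ccccc23)cc1` gives 1300 nM
Compound 2 `Cc1cc(NC(=O)Nc2ccc(F)c(F)c2)c2ccccc2n1` gives 500 nM

Compound 2 holds the lower of these two numbers, and the gap to compound 1 lies beyond the usual scatter of repeated measurements. Among the compounds with values here, with only two values, this is a very short scale, so the position of compound 2 says little on its own.

The next compound is compound 3 `Cc1cc(NC(=O)Nc2cccc(F)c2)c2ccccc2n1` and it has not been measured yet. The structural change from compound 2 is small: hydrogen in place of fluoro on an aromatic carbon in words, hydrogen in place of fluoro on an aromatic carbon. That carbon is ortho to a fluoro group and para to a large group.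

Within the data shown here, no two measured compounds differ in one place only, so the data offer no direct size for this change. In this assay the estimated 1.6-fold higher number from compound 2 to compound 3 (0.20 log units; within the scatter) is a small upward one, and it is not expected to pass the scatter. For compound 3 the expected value is 800 nM within an estimated range of 300 nM to 2200 nM at the likely extremes.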

Compound 3, solubility: 100 nM
Beside the measured number, compound 3's estimate is 8.0-fold (0.90 log units) above it, and the stated range ends above it.
By their numbers in this assay, from the lowest: compound 3; then compound 2; then compound 1.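

Within the data shown here, this is the first direct size for a change at this position: in this assay, putting hydrogen in place of fluoro on the aromatic carbon that is ortho to a fluoro group and para to a large group gives a 5.0-fold lower number from compound 2 to compound 3 (0.70 log units; beyond the scatter), so a change of one atom here moves the read-out by more than the usual scatter. The second new step, with 3-fluorophenyl in place of 4-methylphenyl on an amide-type nitrogen, gives a 13-fold lower number from compound 1 to compound 3 (1.11 log units; beyond the scatter), which is the largest step among the compounds shown and is rated large, whereas the step from the fluoro removal is rated modest. Nothing measured here accounts for either step, so the reason for their size remains unknown.

The compounds shown leave open whether another group on that same carbon, such as chloro, methoxy or an amine, would give a number closer to that of compound 2 or to that of compound 3. They also leave open whether the same swap of fluoro for hydrogen would give a step of similar size in another pair of compounds, since this change is seen in a single pair only.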